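The compounds below may be only part of what the source reports. "The series", "measured", "known", "first", "only" and "open" are said of these compounds alone.

In a functional assay on Ishikawa cells (Homo sapiens) for antiproliferative activity, read by CCK-8 assay, with a stated time of 48 h (a higher number here means a weaker inhibitor, a lower number a stronger inhibitor), two compounds built on a shared core have been measured so far. Compound 1 (`O=C(/C=C/CN1CC(Oc2ccc(Oc3c(-c4ccc(F)cc4)sc4cc(O)ccc34)cc2)C1)N1CCCC1`) gives 9150 nM, and compound 2 (`C/C=C/C(=O)NCCOc1ccc(Oc2c(-c3ccc(F)cc3)sc3cc(O)ccc23)cc1`) gives 12400 nM. These two numbers lie within the usual scatter of repeated measurements, so compound 2 stands level with compound 1 and the two cannot be told apart. Compound 3 (`C=CC(=O)N1CC(Oc2ccc(Oc3c(-c4ccc(F)cc4)sc4cc(O)ccc34)cc2)C1`) keeps the shared core and differs from compound 2 in one place: 1-(vinylcarbonyl)azetidin-3-yl in place of 2-(((prop-1-en-1-yl)carbonyl)amino)ethyl on an oxygen on an aromatic ring. Within the data shown here, no pair of measured compounds shows this kind of change, so the data give no direct size for it, and no step beyond the scatter is expected in this assay. The expected move is small, an estimated 1.4-fold lower number from compound 2 to compound 3 (0.14 log units; within the scatter). Compound 3 is estimated to give 9000 nM, with an expected range of 3500 nM to 20000 nM.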

Compound 3, half-maximal inhibitory concentration: 12300 nM
Compound 3: middle estimate off by 1.4-fold (0.14 log units), on the low side; the measured number falls inside the stated range.
By their numbers in this assay, from the lowest: compounds 1, 3 and 2 (each within the scatter of the next).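

In this assay, 1-(vinylcarbonyl)azetidin-3-yl in place of 2-(((prop-1-en-1-yl)carbonyl)amino)ethyl on the oxygen gives a 1.0-fold lower number from compound 2 to compound 3 (0.00 log units; within the scatter) and so cannot be told apart from the open chain, even though the four-membered ring brings no hydrogen-bond donor where the chain has one. On the ring amine nitrogen, vinylcarbonyl in place of 3-((pyrrolidin-1-yl)carbonyl)prop-2-en-1-yl gives a 1.3-fold higher number from compound 1 to compound 3 (0.13 log units; within the scatter) and is likewise not separated, so neither change moves the result beyond the scatter. No measurement on hand explains these results.

The compounds shown leave open whether any group at this oxygen can separate itself from these three. A larger ring such as piperidine, a longer chain, or a free amine at the chain end would be untested ground here.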